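A few compounds are considered here, and "the series" means these few. Any claim that something is new, unique, unknown or untested is made for them only; others in the source may bear on it.

Measured compounds:
compound 1 `CC1CCN(C(=S)SCc2ccc(C(=O)Nc3ccccc3N)cc2)CC1`, in a functional assay on A-375 cells (Homo sapiens) for antiproliferative activity, read by CCK-8 assay, with a stated time of 72 h, tested at 2 uM (on this read-out higher numbers stand for a stronger effect at the one concentration tested and lower numbers for a weaker effect), compound 1 gives 32.7%;
compound 2 `Nc1ccccc1NC(=O)c1ccc(CSC(=S)N(Cc2ccccc2)Cc2ccccc2)cc1`, in this assay compound 2 gives 10.9%.

Of these two numbers, compound 1 stands highest, with compound 2 lower by a gap beyond the usual scatter. Compound 3 `Nc1ccccc1NC(=O)c1ccc(CSC(=S)N2CCc3ccccc32)cc1` has not yet been measured. It differs from compound 1 in one place: 2,3-dihydro-1H-indol-1-yl in place of 4-methylpiperidin-1-yl on a thiocarbonyl carbon. Among the compounds with values here, no measured pair shows this particular change, so the expectation rests on the two values alone. The step in this assay is expected to be a small drop, a number 7.7 percentage points lower from compound 1 to compound 3 (within the scatter), possibly within the scatter. Compound 3 is therefore estimated at 25%, within a range of 10% to 40%.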

Compound 3, a percentage reported as inhibition, at one concentration (the size of the read-out at that concentration, not a potency): 25.7%
Compound 3: middle estimate off by 0.7 percentage points, on the low side; measured number inside the range.
By their numbers in this assay, from the lowest: compound 2; then compounds 3 and 1 (each within the scatter of the next).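

In this assay, placing 2,3-dihydro-1H-indol-1-yl in place of 4-methylpiperidin-1-yl on a thiocarbonyl carbon gives a number 7 percentage points lower from compound 1 to compound 3 (within the scatter). At this place, then, a group that carries a six-membered aromatic ring of carbon only reads alike with one that carries a six-membered non-aromatic ring. No measurement at hand bears on why the two groups read alike. The compounds shown leave open how an open-chain amine such as diethylamino, or a morpholin-4-yl ring, would read at this place.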